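Swapping a Methyl for a Hydroxy Group on an Aromatic Carbon

The compounds below may be only part of what the source reports. "The series", "measured", "known", "first", "only" and "open" are said of these compounds alone.

Of the compounds shown here, three built on one shared core have been tested in a functional assay on MCF7 cells (Homo sapiens) for antiproliferative activity, read by MTT assay, with a stated time of 72 h; on this read-out higher numbers stand for weaker inhibition and lower numbers for stronger inhibition. Compound 1 `COc1cc(-n2cnc3ccc(-c4ccccc4)cc32)cc(OC)c1OC` gives 2290 nM. Compound 2 `COc1ccc(-c2ccc3ncn(-c4cc(OC)c(OC)c(OC)c4)c3c2)cc1F` gives 520 nM in this assay. Compound 3 `COc1cc(-n2cnc3ccc(-c4cccc(C)c4)cc32)cc(OC)c1OC` gives 360 nM in this assay, the lowest of the three numbers; its gap to compound 2 stays within the scatter, while the step of a 6.4-fold lower number from compound 1 to compound 3 (0.80 log units; beyond the scatter) lies beyond it. For the measured compounds named here, that step, methyl in place of hydrogen on an aromatic carbon, is the only measured change at the position now in question. Compound 4 `COc1cc(-n2cnc3ccc(-c4cccc(O)c4)cc32)cc(OC)c1OC` differs from compound 3 by hydroxy in place of methyl on an aromatic carbon. Going by the values given here, no measured step tests a hydroxy group, so the direction of the change in this assay rests on little evidence, and the improvement seen in the step of a 6.4-fold lower number from compound 1 to compound 3 (0.80 log units; beyond the scatter) may or may not carry over. A modest rise in the number is expected for compound 4, which means an estimated step of a 2.5-fold higher number from compound 3 to compound 4 (0.40 log units; beyond the scatter). Compound 4 is therefore estimated at 900 nM in this assay, within a range from 250 nM to 3500 nM.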

Compound 4, half-maximal inhibitory concentration: 350 nM
For compound 4 the middle estimate is 2.6-fold (0.41 log units) above the measured one; measured number inside the range.
By their numbers in this assay, from the lowest: compounds 4, 3 and 2 (each within the scatter of the next); then compound 1.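

In this assay, hydroxy in place of methyl makes no difference that can be told from the scatter (a 1.0-fold lower number from compound 3 to compound 4 (0.01 log units; within the scatter)), even though hydroxy brings a hydrogen-bond donor and a hydrogen-bond acceptor and methyl brings neither. The gain over the unsubstituted phenyl is therefore not special to methyl, since it also appears with hydroxy (a 6.5-fold lower number from compound 1 to compound 4 (0.82 log units; beyond the scatter)), while the exchange of 3-fluoro-4-methoxyphenyl for 3-hydroxyphenyl also stays within the scatter (a 1.5-fold lower number from compound 2 to compound 4 (0.17 log units; within the scatter)). Nothing shown here explains why the two groups give such similar numbers.

From the compounds shown here alone, whether an amine, a carboxylic acid or a longer chain at this same place would keep the number in this range remains open. Also open, going by these compounds, is whether hydroxy would give a similar result on another carbon of this ring.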